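Benzylic amide series: hydroxy replacing trifluoromethyl on the benzyl ring

The source may hold more compounds than are shown below. What is called first, only, known or untested is meant among the compounds shown, and "the series" means these compounds.

Within the data shown here, compound 1 `Cc1c(C(=O)NCc2cccc(C(F)(F)F)c2)cnn1-c1ccc(Cl)cc1` is the only member with a definite number in a functional assay on cells for antagonist activity at C-C chemokine receptor type 1 (Homo sapiens), read by FLIPR and calcium flux; a higher number here means a weaker inhibitor, a lower number a stronger inhibitor; compound 1 gives 600 nM. Compound 2 `COCc1c(C(=O)NCc2cccc(C(F)(F)F)c2)cnn1-c1ccc(Cl)cc1` reports only a limit in this assay, > 3000 nM, which is the limit of > 3000 nM in this assay, at which 1 of the 2 values shown sits. Among the measured compounds shown here, the one measured step, an at least 5.0-fold higher number from compound 1 to compound 2 (0.69 log units; beyond the scatter), concerns a different site and so bears only weakly on compound 3 `Cc1c(C(=O)NCc2cccc(O)c2)cnn1-c1ccc(Cl)cc1`, which differs from compound 1 by hydroxy in place of trifluoromethyl on an aromatic carbon. Without a matching precedent, a modest loss is expected, a 3.3-fold higher number from compound 1 to compound 3 (0.52 log units; beyond the scatter), so compound 3 is estimated at 2000 nM with range 700 nM to 6000 nM.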

Compound 3, half-maximal inhibitory concentration: > 3000 nM
Compound 3 was reported as a limit; the forecaster's own chance of this, stated with the estimate: 35%; middle value at least 1.5-fold (0.17 log units) from the limit.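

Among these compounds, this is the first reading at the aromatic carbon carrying trifluoromethyl, and that site does not tolerate every replacement: hydroxy in place of trifluoromethyl gives an at least 5.0-fold higher number from compound 1 to compound 3 (0.69 log units; beyond the scatter). In this assay compound 3 gives > 3000 nM, which is a limit and not a number. The true size of the loss therefore stays unresolved: the limit of > 3000 nM in this assay, at which 2 of the 3 values shown sit.

The compounds shown leave open whether a nitrile or a chlorine atom on this carbon would keep a definite number. They also leave open whether an amine there would fare as hydroxy does.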